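Cyano added to the pyridyl of compound 2

The source may hold more compounds than are shown below. What is called first, only, known or untested is meant among the compounds shown, and "the series" means these compounds.

Compound 1 `Nc1nc(-c2cnco2)nc2sc(Cc3ccccc3)cc12` gives 106 nM in a functional assay on CHO-K1 cells for antagonist activity at adenosine receptor A1 (Homo sapiens), read by a beta-galactosidase reporter and cAMP accumulation, with stated times of 15 min and 6 h; on this read-out lower numbers stand for stronger inhibition and higher numbers for weaker inhibition. Compound 2 `Nc1nc(-c2ccccn2)nc2sc(Cc3ccccc3)cc12` gives 3710 nM, the highest of the two numbers; the step of a 35-fold higher number from compound 1 to compound 2 (1.54 log units; beyond the scatter) is the only one measured. Compound 3 `N#Cc1cccc(-c2nc(N)c3cc(Cc4ccccc4)sc3n2)n1` differs from compound 2 by cyano in place of hydrogen on an aromatic carbon, the group sitting next to the ring nitrogen of the six-membered ring. Among the compounds with values here, no measured step involves a cyano for hydrogen exchange, so the only change seen here, from oxazolyl to pyridyl, does not bear on it. Compound 3 is therefore expected to show a 1.2-fold lower number from compound 2 to compound 3 (0.09 log units; within the scatter), an estimate of 3000 nM with a range of 800 nM to 12000 nM.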

Compound 3, inhibition constant: > 1000 nM
Compound 3: a limit, no number (the forecaster's own chance of this, stated with the estimate: 10%); the middle value lies beyond the limit too.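

Compound 3 gives > 1000 nM in this assay, which is a limit and not a number. The cyano-for-hydrogen step from compound 2 therefore cannot be read, so this position next to the ring nitrogen has no measured size of effect yet: the limit of > 1000 nM in this assay, at which 1 of the 3 values shown sits. Replacing 1,3-oxazol-5-yl with 6-cyanopyridin-2-yl gives an at least 9.4-fold higher number from compound 1 to compound 3 (0.97 log units; beyond the scatter), so adding cyano does not bring this pyridyl series up to compound 1.

On these data alone, whether cyano changes inhibition at all relative to hydrogen remains open. Also open, as far as these compounds go, is whether an amine or a methoxy group on this same carbon would give a readable number.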